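Methyl to Fluoro on the Aroyl Ring

The source may hold more compounds than are shown below. What is called first, only, known or untested is meant among the compounds shown, and "the series" means these compounds.

Measured so far:
Compound 2, `COc1cc(-c2nnc3n2NC(c2cccs2)C(C(=O)c2ccc(C)cc2)S3)cc(OC)c1OC`, gives 12700 nM.
Compound 1, `COc1cc(-c2nnc3n2NC(c2ccco2)C(C(=O)c2ccccc2C)S3)cc(OC)c1OC`, gives 80000 nM.

These numbers come from a functional assay on A549 cells (Homo sapiens) for cytotoxicity, read by MTT assay, with a stated time of 48 h; a lower number here means a stronger inhibitor, a higher number a weaker inhibitor. Compound 2 stands at the lowest of the two numbers; compound 1, which differs from it in more than one place, sits at a higher number, and the gap between them lies beyond the usual scatter of the measurement. Among the measured compounds shown here, no single-change step between measured compounds is available here, so there is nothing yet that tells how a change on the aroyl ring alone shifts the number.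

Compound 3, `COc1cc(-c2nnc3n2NC(c2cccs2)C(C(=O)c2ccc(F)cc2)S3)cc(OC)c1OC`, is the next compound. It differs from compound 2 in one place: fluoro in place of methyl on an aromatic carbon. Both groups are small, neither adds a donor or an acceptor, and the rest of the molecule is unchanged. For the measured compounds named here, with no measured step of this kind to lean on, the expectation is a step of modest size or none beyond the scatter, in either direction, a 1.2-fold higher number from compound 2 to compound 3 (0.07 log units; within the scatter). Compound 3 is therefore estimated at 15000 nM in this assay , with a range from 5000 nM to 45000 nM.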

Compound 3, half-maximal inhibitory concentration: 45000 nM
Compound 3: middle estimate off by 3.0-fold (0.48 log units), on the low side, and the stated range covers the measured number.
By their numbers in this assay, from the lowest: compound 2; then compounds 3 and 1 (each within the scatter of the next).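

Among the compounds shown here, the swap of 4-methylphenyl to 4-fluorophenyl gives the first single-change reading in this set: in this assay there is a 3.5-fold higher number from compound 2 to compound 3 (0.55 log units; beyond the scatter). With the rest of the molecule unchanged, this position on the aroyl ring, para to a large group, is not indifferent to a one-atom exchange, even though the counts of hydrogen-bond donors and acceptors stay the same. Nothing available explains why the number moves in this direction.

The compounds shown leave open how an amine, a methoxy group or a longer alkyl chain at this position would compare with the methyl of compound 2. They also leave open whether fluoro in place of methyl gives a similar step when another part of the molecule is different.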